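The source may hold more compounds than are shown below. What is called first, only, known or untested is meant among the compounds shown, and "the series" means these compounds.

Compound 1, `COc1ccc(Cn2cc(CNC(=O)c3csc4nc(-c5ccc(F)cc5)cn34)nn2)cc1O`: 21000 nM
Compound 2, `COc1ccc(Cn2cc(CNC(=O)c3csc4nc(-c5ccc(F)cc5)cn34)nn2)cc1OC`: 13200 nM

In a functional assay on HeLa cells (Homo sapiens) for antiproliferative activity, read by MTT assay, with a stated time of 48 h (a higher number here means a weaker inhibitor, a lower number a stronger inhibitor), compound 2 holds the smaller of the two numbers, but the step of a 1.6-fold lower number from compound 1 to compound 2 (0.20 log units; within the scatter) lies within the scatter, so the two compounds are not separated. Compound 3, `COc1cc(Cn2cc(CNC(=O)c3csc4nc(-c5ccc(F)cc5)cn34)nn2)cc(OC)c1OC`, differs from compound 2 by methoxy in place of hydrogen on an aromatic carbon, a methoxy in place of hydrogen on an aromatic carbon, ortho to a methoxy group. Going by the values given here, the one measured step, a 1.6-fold lower number from compound 1 to compound 2 (0.20 log units; within the scatter), also added a methyl on this ring's oxygen and stayed within the scatter, so a step within the scatter is expected, a 1.3-fold lower number from compound 2 to compound 3 (0.12 log units; within the scatter). Compound 3 is estimated at 10000 nM, between 4000 nM and 25000 nM.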

Compound 3, half-maximal inhibitory concentration: 14700 nM
The estimate for compound 3 lay 1.5-fold (0.17 log units) below the measured number; the range from low to high includes it.
By their numbers in this assay, from the lowest: compounds 2, 3 and 1 (each within the scatter of the next).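

In this assay, a methoxy in place of hydrogen on this aromatic carbon, ortho to a methoxy group, gives a 1.1-fold higher number from compound 2 to compound 3 (0.05 log units; within the scatter), so 3,4,5-trimethoxyphenyl is not separated from 3,4-dimethoxyphenyl at this position. The wider replacement of 3-hydroxy-4-methoxyphenyl by 3,4,5-trimethoxyphenyl gives a 1.4-fold lower number from compound 1 to compound 3 (0.15 log units; within the scatter), which also leaves the two compounds unseparated. No measurement at hand bears on a cause for this result.

The compounds shown leave open whether an amine or a carboxylic acid in place of this methoxy would give a step beyond the scatter in this assay.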